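A Larger Group Replaces Methoxy on Compound 1

This account rests on a few compounds, and the source may have more. Where it says the series, first, only, none or still open, it means among the compounds named here.

Within the data shown here, in a functional assay on NCI-H460 cells (Homo sapiens) (on this read-out higher numbers stand for an effect only at larger amounts of compound and lower numbers for an effect already at smaller amounts), compound 1 `COc1cc(C2OC(c3ccc(N)c(C)c3)=NN2C(C)=O)cc(OC)c1OC` gives 0.059 uM, the lower of the two numbers measured so far, while compound 2 `COc1cc(C2OC(c3cccc(N(C)C)c3)=NN2C(C)=O)cc(OC)c1OC` gives 0.26 uM. Compound 3 `CCCCNC(=O)c1c(OC)cc(C2OC(c3ccc(N)c(C)c3)=NN2C(C)=O)cc1OC` keeps the 4-amino-3-methylphenyl group of compound 1 but has butylcarbamoyl in place of methoxy on an aromatic carbon, ortho to two methoxy groups: butylcarbamoyl in place of methoxy on an aromatic carbon.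

Among the measured compounds shown here, only one measured step is available as a guide. That step, a 4.4-fold higher number from compound 1 to compound 2 (0.64 log units; beyond the scatter), is a modest change beyond the scatter, made by putting 3-(dimethylamino)phenyl in place of 4-amino-3-methylphenyl. It leaves the methoxy groups untouched, so it gives only a rough idea of how far one swap can move the number and says nothing direct about this one. For the measured compounds named here, no measured compound shows a change at the methoxy position, so the direction is a judgement. With compound 1 already at the lower end at 0.059 uM, a rise seems more likely than a fall. The expected change is a 6.8-fold higher number from compound 1 to compound 3 (0.83 log units; beyond the scatter) in this assay, somewhat larger than the measured step. For compound 3, the estimated value is 0.4 uM, with an expected range from 0.08 uM to 3 uM.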

Compound 3, concentration for half-maximal effect: 60 uM
Beside the measured number, compound 3's estimate is 150-fold (2.18 log units) below it, outside the stated range (above it).
By their numbers in this assay, from the lowest: compound 1; then compound 2; then compound 3.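

The position ortho to two methoxy groups turns out to be far from tolerant of change: in this assay, replacing methoxy with butylcarbamoyl gives a 1000-fold higher number from compound 1 to compound 3 (3.01 log units; beyond the scatter), a large step. This single swap at the aromatic carbon moves the number much further than the earlier change on the other aromatic group, a 4.4-fold higher number from compound 1 to compound 2 (0.64 log units; beyond the scatter), so this is the most sensitive place among the changes shown so far. The swap exchanges methoxy, with 2 heavy atoms and 0 hydrogen-bond donors, for butylcarbamoyl, with 7 heavy atoms and 1 hydrogen-bond donor, but no measurement here bears on why the number climbs so steeply.

Still open, as far as these compounds go, is which part of the new group matters most, the butyl chain or the amide itself, or whether losing the methoxy alone accounts for the step; a methylcarbamoyl group, an ethoxy group or a hydroxyl group at this carbon would help tell these apart. From the compounds shown here alone, it is also open whether the same swap would act as strongly on compound 2, which carries 3-(dimethylamino)phenyl instead of 4-amino-3-methylphenyl.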